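The source may report more compounds than this note shows. Statements on the series, on what has been measured and on what is new or still open speak of the compounds shown alone.

Working notes on the series. The measure throughout is a functional assay on CHO cells for antagonist activity at adenosine receptor A2b (Homo sapiens); on this read-out lower numbers stand for stronger inhibition and higher numbers for weaker inhibition. Compound 1 (`CCOC(=O)c1nc(N)nc2nn(CC(C)(C)C)cc12`) gives only a limit in this assay, > 15000 nM. Compound 2 (`CCOC(=O)c1nc(NC(=O)c2ccc(F)cc2)nc2nn(C)cc12`) likewise gives only a limit, > 20000 nM. Compound 3 (`CCOC(=O)c1nc(NC(=O)c2ccccc2)nc2nn(C(C)C)cc12`) gives only a limit as well, > 10000 nM. Within the data shown here, compound 3 thus stands among three limits and no number: none of the three compounds measured so far yields an inhibition constant that can be placed, and no step between them can be read off. Compound 4 (`CCOC(=O)c1nc(NC(=O)c2ccc(C(F)(F)F)cc2)nc2nn(C(C)C)cc12`) differs from compound 3 by trifluoromethyl in place of hydrogen on an aromatic carbon. Among the measured compounds shown here, with every value so far a limit, nothing in these data shows whether this change moves the inhibition constant in either direction, and the step that is expected is a step that the limit leaves unreadable from compound 3 to compound 4, that is, no movement expected beyond the scatter. The inhibition constant for compound 4 is estimated at 20000 nM, within 5000 nM to 100000 nM, with a strong chance that this assay again reports only a limit.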

Compound 4, inhibition constant: > 20000 nM
Compound 4: no number, only a limit (the forecaster's own chance of this, stated with the estimate: 80%); the middle value lies on the limit itself.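

Compound 3 and compound 4 both give only limits in this assay, so no step can be read between them for trifluoromethyl in place of hydrogen on an aromatic carbon. The compounds shown leave open whether any change moves the inhibition constant in this series.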